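Swapping the pyrimidine for a phenylcarbamoyl group

The source may report more compounds than this note shows. Statements on the series, on what has been measured and on what is new or still open speak of the compounds shown alone.

Measured compounds:
Compound 1, `CCOc1ccnc(N2CCN(c3cc(N)c4cc(OC)c(OC)cc4n3)CC2)n1`: 0.42 nM
Compound 2, `COc1cc2nc(N3CCN(c4ccccc4)CC3)cc(N)c2cc1OC`: 1.72 nM
Compound 3, `COc1cc2nc(N3CCN(c4nccc(N(C)C)n4)CC3)cc(N)c2cc1OC`: 0.46 nM

In an assay on brain for displacement of a labelled ligand from Adrenergic receptor alpha-1 (Rattus norvegicus) (a higher number here means a weaker inhibitor, a lower number a stronger inhibitor), compound 1 gives the lowest of the three numbers. Compound 3 sits nearest to it, with a 1.1-fold higher number from compound 1 to compound 3 (0.04 log units; within the scatter), a gap that lies within the scatter, so no order between these two can be claimed. Compound 2 sits furthest, with a 4.1-fold higher number from compound 1 to compound 2 (0.61 log units; beyond the scatter), a modest step beyond the scatter.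

Compound 4, `COc1cc2nc(N3CCN(C(=O)Nc4ccccc4)CC3)cc(N)c2cc1OC`, has not yet been measured. It differs from compound 1 in one place: phenylcarbamoyl in place of 4-ethoxypyrimidin-2-yl on an amine nitrogen in a ring. The change most relevant to this one is the step from compound 1 to compound 2, where a phenyl alone replaced the same 4-ethoxypyrimidin-2-yl on the ring nitrogen and gave a 4.1-fold higher number from compound 1 to compound 2 (0.61 log units; beyond the scatter). The step from compound 2 to compound 3, a 3.7-fold lower number from compound 2 to compound 3 (0.57 log units; beyond the scatter), shows the same contrast from the other side. Within the data shown here, no measured pair shows a phenylcarbamoyl group at this position, so its effect is not known directly.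

Since the phenyl in compound 2 produced a 4.1-fold higher number from compound 1 to compound 2 (0.61 log units; beyond the scatter), a modest loss of the same kind is expected for compound 4, that is a 6.0-fold higher number from compound 1 to compound 4 (0.77 log units; beyond the scatter). The estimate for compound 4 is therefore 2.5 nM, with a range from 0.6 nM to 10 nM.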

Compound 4, inhibition constant: 0.34 nM
The estimate for compound 4 lay 7.4-fold (0.87 log units) above the measured number; the whole stated range lies above it.
By their numbers in this assay, from the lowest: compounds 4, 1 and 3 (each within the scatter of the next); then compound 2.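

In this assay, the phenylcarbamoyl group on the ring nitrogen gives numbers that cannot be told apart from those of the pyrimidines, with a 1.2-fold lower number from compound 1 to compound 4 (0.09 log units; within the scatter) and a 1.4-fold lower number from compound 3 to compound 4 (0.13 log units; within the scatter) both read as no order, so a pyrimidine is not required at this position for values of this size. Among these compounds, the earlier compounds showed a phenyl ring at this nitrogen only in the form attached directly, and the comparison a 5.1-fold lower number from compound 2 to compound 4 (0.70 log units; beyond the scatter) now shows that placing a carbonyl and an amide nitrogen ahead of the same ring, the one difference in that pair, goes with a number beyond the scatter and back among those of the pyrimidines. Nothing available here explains why the phenylcarbamoyl group behaves this way.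

The compounds shown leave open whether the carbonyl or the amide hydrogen matters more, since a benzoyl group on the same ring nitrogen is not among them. They also leave open how much the far end tolerates, for instance a chlorine on the phenyl ring or a longer chain ahead of it.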